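Hydrogen for Chloro: a Repeated Change in Cytotoxicity

The compounds below may be only part of what the source reports. "The series", "measured", "known", "first", "only" and "open" are said of these compounds alone.

Compound 1 `ClCc1ccc(Cn2cnc3nc(Cl)nc(Cl)c32)cc1` gives 1440 nM in a functional assay on M14 cells (Homo sapiens) for cytotoxicity, read by sulforhodamine B assay, with a stated time of 48 h; a lower number here means a stronger inhibitor of growth, a higher number a weaker inhibitor of growth. Compound 3 `ClCc1ccccc1Cn1cnc2nc(Cl)nc(Cl)c21` gives 1860 nM in this assay, and compound 2 `ClCc1ccccc1Cn1cnc2ncnc(Cl)c21` gives 1900 nM. Compound 1 and compound 3 are built from the same atoms joined differently; the difference between the two cores is not broken down here. From compound 3 to compound 2 the change is hydrogen in place of chloro on an aromatic carbon, and it made a 1.0-fold higher number from compound 3 to compound 2 (0.01 log units; within the scatter). Compound 4 `ClCc1ccc(Cn2cnc3ncnc(Cl)c32)cc1` has not yet been measured in this assay; it differs from compound 1 by the same change, (hydrogen in place of chloro on an aromatic carbon). The expected step is a 1.0-fold higher number from compound 1 to compound 4 (0.02 log units; within the scatter), because compound 3 to compound 2 showed a 1.0-fold higher number from compound 3 to compound 2 (0.01 log units; within the scatter) and compound 1 stands at 1440 nM. Compound 4 is therefore estimated at 1500 nM, expected to fall between 750 nM and 3000 nM.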

Compound 4, concentration for 50% growth inhibition: 2750 nM
The estimate for compound 4 lay 1.8-fold (0.26 log units) below the measured number; the range from low to high includes it.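

On the core of compound 1, hydrogen in place of chloro on an aromatic carbon gave a 1.9-fold higher number from compound 1 to compound 4 (0.28 log units; within the scatter) in this assay. Set beside the earlier step, the two cores cannot be told apart: the same change on two cores in this assay, a 1.0-fold higher number (0.01 log units; within the scatter) from compound 3 to compound 2 and a 1.9-fold higher number (0.28 log units; within the scatter) from compound 1 to compound 4, 1.9-fold (0.27 log units) apart, within the scatter of two such steps. This shows that the change carried across these two cores without a step beyond the scatter, but it does not show that the step has the same size on both, and two pairs say nothing about other cores.

The compounds shown hold only chloro or hydrogen on this carbon. From the compounds shown here alone, what an amine, a methoxy group or a longer chain would give there stays open.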